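The compounds below may be only part of what the source reports. "The series", "measured", "known", "first", "only" and "open" are said of these compounds alone.

Measured compounds:

- Compound 1, `CC1(c2ccccc2)NC(=O)N(Cc2ccc(C(=O)NO)cc2)C1=O`, in an assay on isolated protein for inhibition of protein deacetylase HDAC6 (Homo sapiens), read by fluorescence, with stated times of 10 min and 2 h (on this read-out lower numbers stand for stronger inhibition and higher numbers for weaker inhibition), gives 74.9 nM.
- Compound 2, `CCCC1(c2ccccc2)NC(=O)N(Cc2ccc(C(=O)NO)cc2)C1=O`, in this assay gives 50.9 nM.
- Compound 3, `CC(C)CC1C(=O)N(Cc2ccc(C(=O)NO)cc2)C(=O)N1C`, in this assay gives 251 nM.

Compound 1 and compound 2 share one core and differ in a single spot: ethyl in place of hydrogen on a saturated chain carbon bound to a saturated ring carbon. In this assay this gave a 1.5-fold lower number from compound 1 to compound 2 (0.17 log units; within the scatter), so the two numbers cannot be told apart with confidence. Compound 3 is built on a different core; the difference between the two cores is not broken down here. Its number in this assay stands beyond the scatter from both compound 1 and compound 2, so it is the weakest inhibitor of the three measured.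

Compound 4, `CCCN1C(=O)N(Cc2ccc(C(=O)NO)cc2)C(=O)C1CC(C)C`, is compound 3 with one addition: ethyl in place of hydrogen on a saturated chain carbon bound to an amide-type nitrogen in a ring. The same kind of change was made from compound 1 to compound 2, but the place is not the same: there the ethyl entered on a saturated chain carbon bound to a saturated ring carbon, here it enters on a saturated chain carbon bound to an amide-type nitrogen in a ring. Among the measured compounds shown here, because the earlier step of the same kind was a 1.5-fold lower number from compound 1 to compound 2 (0.17 log units; within the scatter), the expectation for compound 4 in this assay is a step of about a 1.3-fold lower number from compound 3 to compound 4 (0.12 log units; within the scatter), with the added caution that only one prior example exists and its place differs. Compound 4 is therefore estimated at 190 nM in this assay, expected to fall between 80 nM and 450 nM.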

Compound 4, half-maximal inhibitory concentration: 174 nM
Estimate against measurement, compound 4: 1.1-fold (0.04 log units) above; the range from low to high includes it.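

In this assay, putting the ethyl on compound 3 gave a 1.4-fold lower number from compound 3 to compound 4 (0.16 log units; within the scatter), so these two numbers cannot be told apart with confidence. Set beside the earlier step, the same change looks alike on the two cores, even though it sits at a different place on each: the same change on two cores in this assay, a 1.5-fold lower number (0.17 log units; within the scatter) from compound 1 to compound 2 and a 1.4-fold lower number (0.16 log units; within the scatter) from compound 3 to compound 4, 1.0-fold (0.01 log units) apart, within the scatter of two such steps. This agreement shows only that, in these two cases, the ethyl brought no change large enough to stand out from the ordinary noise of the measurement; it does not show a real gain in inhibition, and two small steps cannot establish a rule that would carry over to further cores.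

The compounds shown leave open what larger or chemically different groups would do at these places, such as a longer chain like hexyl, an amine or a carboxylic acid, any of which might produce a step clearly beyond the scatter. Also open, on these data alone, is whether such a step would then keep its size from one core to the other, which is the real test of carrying a change across this series.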